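A methyl step and an acetoxymethyl swap

This account rests on a few compounds, and the source may have more. Where it says the series, first, only, none or still open, it means among the compounds named here.

In a functional assay on T29Kt1 cells (Homo sapiens) for cytotoxicity, read by sulforhodamine B assay, with a stated time of 3 days (on this read-out higher numbers stand for weaker inhibition and lower numbers for stronger inhibition), three compounds have been measured so far. Compound 1 (`CC(C)Cn1cc(C=O)c2ccccc21`) gives only a limit of > 31600 nM and no number. Compound 2 (`OCc1cn(Cc2ccc(Cl)cc2)c2ccccc12`) gives 79 nM and compound 3 (`CC(O)c1cn(Cc2ccc(Cl)cc2)c2ccccc12`) gives 19900 nM on the same read-out. Compound 3 therefore holds the higher of the two true numbers, with compound 2 as its nearest neighbour.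

Compound 4 (`CC(=O)OCc1cn(Cc2ccc(Cl)cc2)c2ccccc12`) has acetoxymethyl in place of 1-hydroxyethyl on an aromatic carbon. Going by the values given here, one measured step bears on this change. It shows a 250-fold higher number from compound 2 to compound 3 (2.40 log units; beyond the scatter) for a methyl in place of hydrogen on the saturated chain carbon bound to an aromatic carbon and an oxygen, a large step. Acetoxymethyl lacks that methyl, a feature it shares with compound 2 at 79 nM in this assay and one that points towards a much lower number. Among the compounds with values here, no measured step covers the rest of the change, which leaves the expectation loose and argues against assuming the full size of that step. The expected move is large and downward, towards stronger inhibition (a 66-fold lower number from compound 3 to compound 4 (1.82 log units; beyond the scatter)). Compound 4 is estimated to give 300 nM (expected range 50 nM to 4000 nM).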

Compound 4, half-maximal inhibitory concentration: 63 nM
For compound 4 the middle estimate is 4.8-fold (0.68 log units) above the measured one; the range from low to high includes it.
By their numbers in this assay, from the lowest: compounds 4 and 2 (each within the scatter of the next); then compound 3. At a limit, above all of these: compound 1.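

At this position, two ring bonds from the ring nitrogen, acetoxymethyl in place of 1-hydroxyethyl gives a 320-fold lower number from compound 3 to compound 4 (2.50 log units; beyond the scatter) in this assay, so this one change undoes the large rise that came with the methyl on the chain carbon. Acetyl in place of hydrogen on the oxygen gives a 1.3-fold lower number from compound 2 to compound 4 (0.10 log units; within the scatter) and stays within the scatter, which shows that on this read-out the oxygen of compound 2 can carry acetyl without a measurable change. Read with a 250-fold higher number from compound 2 to compound 3 (2.40 log units; beyond the scatter) and set against the two new steps, this places the high number of compound 3 with the methyl on the chain carbon, since compound 2 and compound 4 both lack that methyl and differ from each other on the oxygen without a change beyond the scatter.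

Nothing among the measurements shown gives a reason for these steps. As far as these compounds go, it remains open whether a longer acyl chain or a methyl ether on that oxygen, or an amine or a carboxylic acid in place of the hydroxyl, would keep the number of compound 2, and whether acetyl on the oxygen of compound 3 would still leave the methyl's full effect.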